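Reshuffling the Side Chain of Compound 2

The source may report more compounds than this note shows. Statements on the series, on what has been measured and on what is new or still open speak of the compounds shown alone.

Of the compounds shown here, three sharing one core have been tested in a functional assay on the whole organism with Rattus norvegicus as the target, at a dose of 100 mg/kg; on this read-out higher numbers stand for more inhibition at the one dose given (going by the name of the read-out) and lower numbers for less inhibition. Compound 1 `CC/N=C(/NC#N)NCCCn1nc(-c2ccccc2)cc(C)c1=O` gives 23.5%, compound 2 `CC/N=C(/NC#N)NCCCn1nc(-c2ccccc2)ccc1=O` gives 62.9%, and compound 3 `CC/N=C(/NC#N)NCCCn1nc(C)ccc1=O` gives 34.5%. Compound 2 stands highest of the three; the nearest is compound 3, and the step of a number 28.4 percentage points lower from compound 2 to compound 3 (beyond the scatter) came with methyl in place of phenyl on an aromatic carbon. The step of a number 39.4 percentage points higher from compound 1 to compound 2 (beyond the scatter) came with hydrogen in place of methyl on an aromatic carbon.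

Compound 4 `CN(C)/C(=N/CCCn1nc(-c2ccccc2)ccc1=O)NC#N` has not yet been measured. It differs from compound 2 in that (a group of 8 heavy atoms (4 carbon, 4 nitrogen; no ring) in place of a group of 8 heavy atoms (4 carbon, 4 nitrogen; no ring), on a saturated chain carbon, three bonds along the chain from an aromatic nitrogen). Going by the values given here, both measured steps changed a group on an aromatic carbon of the shared core; neither touched the side chain, so no measured step bears on this change, and its effect on this assay is unknown from the data at hand. With nothing to go on beyond the value of compound 2 itself, no step beyond the scatter is predicted, but the uncertainty is wide. Compound 4 is therefore expected to give about 55%, within a range from 25% to 80%. This estimate means a step of a number 7.9 percentage points lower from compound 2 to compound 4 (within the scatter), so essentially no change beyond the scatter is expected.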

Compound 4, a percentage reported as inhibition, in the whole organism at one dose (the size of the read-out at that dose, not a potency): 72.2%
Compound 4: the middle estimate sits 17.2 percentage points below what was measured, and the stated range covers the measured number.
By their numbers in this assay, from the lowest: compound 1; then compound 3; then compounds 2 and 4 (each within the scatter of the next).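

Going by these compounds alone, the side chain is now varied for the first time, as the earlier steps changed only groups on an aromatic carbon of the shared core. In this assay, swapping one group of 8 heavy atoms for another built from the same atoms, on a saturated chain carbon, three bonds along the chain from an aromatic nitrogen, gives a step of a number 9.3 percentage points higher from compound 2 to compound 4 (within the scatter), even though the group that enters has 1 hydrogen-bond donor where the group that leaves has 2 hydrogen-bond donors. This rearrangement therefore leaves the read-out within the usual scatter, whereas the two core changes, a number 39.4 percentage points higher from compound 1 to compound 2 (beyond the scatter) and a number 28.4 percentage points lower from compound 2 to compound 3 (beyond the scatter), both lie beyond it, and no independent measurement is available to explain this difference.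

Going by these compounds, with a single side-chain change, it remains open whether this end of the molecule would accept something more different, such as a piperidine ring or a carboxylic acid in place of the group, or whether a longer chain to the core would matter. Each number is also a reading at one dose, so the compounds shown give no measure of potency.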